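Amine swap on the shared core: piperidine to dipropylamine

This account rests on a few compounds, and the source may have more. Where it says the series, first, only, none or still open, it means among the compounds named here.

In a functional assay on MCF7 cells (Homo sapiens) for inhibition, read by sulforhodamine B assay (on this read-out higher numbers stand for weaker inhibition and lower numbers for stronger inhibition), compound 1 (`O=C1C(Nc2ccc(Br)cc2)=CC(=O)c2c1nc1n2[C@H]2OC[C@@H](O)[C@H]2OC1`) gives 4330 nM. Compound 2 (`COc1ccccc1NC1=CC(=O)c2c(nc3n2[C@H]2OC[C@@H](O)[C@H]2OC3)C1=O`) gives 6580 nM. Compound 3 (`O=C1C(N2CCCCC2)=CC(=O)c2c1nc1n2[C@H]2OC[C@@H](O)[C@H]2OC1`) gives > 8000 nM, which is a limit of the assay and not a number. Compound 3 therefore stands at the limit of > 8000 nM in this assay, at which 1 of the 3 values shown sits.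

Compound 4 (`CCCN(CCC)C1=CC(=O)c2c(nc3n2[C@H]2OC[C@@H](O)[C@H]2OC3)C1=O`) carries dipropylamino in place of piperidin-1-yl on a double-bonded ring carbon.

Two measured steps change the group at this carbon: an at least 1.8-fold higher number from compound 1 to compound 3 (0.26 log units; that floor lies within the scatter) and an at least 1.2-fold higher number from compound 2 to compound 3 (0.08 log units; that floor lies within the scatter). Both are floors that lie within the scatter. The step between the two aryl amines, a 1.5-fold higher number from compound 1 to compound 2 (0.18 log units; within the scatter), is also within the scatter. Among the compounds with values here, no measured step replaces the piperidin-1-yl ring with an open chain, so the series offers no direct precedent for this change. Given these small steps, no change beyond the scatter is expected in this assay, and no direction is favoured. The result may again be reported only as a limit.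

The estimated change is a step that the limit leaves unreadable from compound 3 to compound 4. For compound 4 the expected value is 8500 nM, with an estimated range of 4000 nM to 18000 nM.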

Compound 4, half-maximal inhibitory concentration: > 16000 nM
Compound 4 ended at the assay's limit (the forecaster's own chance of this, stated with the estimate: 50%); middle value at least 1.8-fold (0.27 log units) away from the limit.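

In this assay, within the data shown here, the dipropylamino group gives the first steps at this double-bonded ring carbon that reach beyond the scatter: an at least 2.4-fold higher number from compound 2 to compound 4 (0.38 log units; beyond the scatter), and an at least 3.6-fold higher number from compound 1 to compound 4 (0.56 log units; beyond the scatter). The reading for compound 4 is a limit of the assay and not a number: the limit of > 16000 nM in this assay, at which 1 of the 4 values shown sits. Compound 3 also stands at a limit, so the step between the piperidin-1-yl ring and the open chain cannot be read, and among the compounds shown only the aryl amines, compound 1 and compound 2, give numbers, while compound 3 and compound 4 give limits only.

On these data alone, whether the open chain differs from the piperidin-1-yl ring at all therefore stays open, as does whether any amine at this carbon without an aryl group gives a readable value in this assay. A propylamino group, which keeps one propyl chain and the amine hydrogen found in compound 1 and compound 2, or a benzylamino group would test whether that hydrogen or the aryl group goes with the measurable values.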